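From Cyano to Carboxy: A Cytotoxicity Step Awaited

The source may report more compounds than this note shows. Statements on the series, on what has been measured and on what is new or still open speak of the compounds shown alone.

Compound 1 `COc1ccc(-c2cc3cccc(OC)c3nc2O)cc1`: 10000 nM
Compound 2 `COc1ccc(-c2cc3c(OC)cc(OC)cc3n(CC#N)c2=O)cc1`: 10000 nM

Both compounds were tested in a functional assay on U-373MG ATCC cells for cytotoxicity against U373 MG (Homo sapiens), read by colorimetric assay and MTT assay; a higher number here means a weaker inhibitor, a lower number a stronger inhibitor. Compound 2 stands level with compound 1 in this assay, and the two show no difference beyond the usual scatter of repeated measurements. They differ in more than one place on the shared core, so this pair does not isolate the effect of any single change.

The next compound, compound 3 `COc1ccc(-c2cc3c(OC)cc(OC)cc3n(CC(=O)O)c2=O)cc1`, differs from compound 2 in one place only (carboxy in place of cyano on a saturated chain carbon bound to an aromatic nitrogen). In words, it has carboxy in place of cyano on a saturated chain carbon bound to an aromatic nitrogen. Among the compounds with values here, no measured pair shows what this exchange does, so the only anchor is compound 2 at 10000 nM. On that basis, no shift beyond the scatter is expected in either direction in this assay. The expected change is no change at the digits printed from compound 2 to compound 3 (within the scatter), which is an estimate and not a measurement. For compound 3 the estimated value is 10000 nM, with an expected range from 5000 nM to 20000 nM.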

Compound 3, half-maximal inhibitory concentration: 10000 nM
Compound 3: the middle estimate sits on the measured number at the digits printed, and the stated range covers the measured number.
By their numbers in this assay, from the lowest: compounds 1, 2 and 3 (each within the scatter of the next).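

In this assay, within the data shown here, carboxy in place of cyano on a saturated chain carbon bound to an aromatic nitrogen brings no change at the digits printed from compound 2 to compound 3 (within the scatter) and gives the first reading of a change at this place alone. Compound 1 and compound 2 differ in more than one place, whereas this pair shows that the exchange of cyanomethyl for carboxymethyl, which brings in a hydrogen-bond donor that cyano lacks, leaves the number where it stood in this assay. No measurement shown here offers an explanation for this result.

From the compounds shown here alone, this single step says nothing about how other groups would behave at this place, so it remains open whether an amine, a primary amide or a longer chain ending in a carboxylic acid would move the value in either direction. The separate contribution of each difference between compound 1 and compound 2 also remains unresolved, since no compound shown changes those places one at a time.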